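Aryl hydrazone swap on compound 2: expected cytotoxicity

The source may hold more compounds than are shown below. What is called first, only, known or untested is meant among the compounds shown, and "the series" means these compounds.

Compound 2 `CN(C)c1ccc(/C=N/NC(=O)CCN2CCN(c3ccnc4cc(Cl)ccc34)CC2)cc1` is measured in an ADME assay on cells (Splenocyte, Mus musculus, strain BALB/c) for cytotoxicity, read by thymidine incorporation, with a stated time of 24 h (on this read-out lower numbers stand for stronger inhibition and higher numbers for weaker inhibition), only as a limit, > 100000 nM, so on the numbers shown it sits at the top end (the limit of > 100000 nM in this assay, at which 1 of the 3 values shown sits). Compound 3 `O=C(CCN1CCN(c2ccnc3cc(Cl)ccc23)CC1)N/N=C/c1ccccc1O` gives 11500 nM, and compound 1 `COc1cc(/C=N/NC(=O)CCN2CCN(c3ccnc4cc(Cl)ccc34)CC2)c(Br)c(OC)c1OC` gives 9600 nM. The step from compound 2 to compound 3 is an at least 8.6-fold lower number from compound 2 to compound 3 (0.93 log units; beyond the scatter). Compound 4 `COc1cc(/C=N/NC(=O)CCN2CCN(c3ccnc4cc(Cl)ccc34)CC2)ccc1OC(C)C` differs from compound 2 by 4-isopropoxy-3-methoxyphenyl in place of 4-(dimethylamino)phenyl on a carbon with a double bond to nitrogen. Within the data shown here, the one step that bears on it, the replacement of 4-(dimethylamino)phenyl by another aryl group, moved the number down by at least a modest amount; compound 1, carrying another oxygen-substituted aryl, lands close to compound 3. For compound 4 a step of an at least 6.6-fold lower number from compound 2 to compound 4 (0.82 log units; beyond the scatter) is therefore expected. Compound 4 is estimated at 15000 nM, within 5000 nM to 80000 nM.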

Compound 4, half-maximal inhibitory concentration: 8800 nM
Compound 4: the middle estimate sits 1.7-fold (0.23 log units) above what was measured; the range from low to high includes it.
By their numbers in this assay, from the lowest: compounds 4, 1 and 3 (each within the scatter of the next). At a limit, above all of these: compound 2.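

In this assay, 4-isopropoxy-3-methoxyphenyl in place of 4-(dimethylamino)phenyl gives an at least 11-fold lower number from compound 2 to compound 4 (1.05 log units; beyond the scatter). The reading for compound 2 is a limit: the limit of > 100000 nM in this assay, at which 1 of the 4 values shown sits. Against 2-hydroxyphenyl, the same group gives a 1.3-fold lower number from compound 3 to compound 4 (0.12 log units; within the scatter), so an aryl group without a hydroxyl reads level with compound 3, and only compound 2 stands apart among the four.

As far as these compounds go, whether a primary amine or a carboxylic acid on the aryl ring at this place would also reach the limit stays open. From the compounds shown here alone, the separate shares of the methoxy and isopropoxy groups also remain open.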